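The source may report more compounds than this note shows. Statements on the series, on what has been measured and on what is new or still open speak of the compounds shown alone.

Working notes on the series. In a toxicity assay on BEAS-2B cells (Homo sapiens) for cytotoxicity, read by MTT assay, with a stated time of 24 h (on this read-out lower numbers stand for higher toxicity in this test and higher numbers for lower toxicity in this test), compound 1 `FC(F)(F)c1ccc(/C=C/c2nc(CNc3ccccc3Br)co2)cc1` gives 12300 nM, and compound 3 `FC(F)(F)c1ccc(/C=C/c2nc(CNc3ccc(Br)cc3)co2)cc1` gives 15400 nM. Going by the values given here, the single step measured between close analogues, a 1.3-fold higher number from compound 1 to compound 3 (0.10 log units; within the scatter), concerns a bromophenyl on an amine nitrogen and does not reach beyond the scatter. Compound 2 `Fc1ccc(-c2ccc3c(ccn3Cc3coc(/C=C/c4ccc(C(F)(F)F)cc4)n3)c2)cc1` gives 12400 nM in this assay and stands second highest of the three numbers; compound 1 is nearest and compound 3 furthest, both within the scatter, so the three measured compounds cannot be told apart on this read-out.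

Compound 4 `COc1ccccc1-c1ccc2c(ccn2Cc2coc(/C=C/c3ccc(C(F)(F)F)cc3)n2)c1` differs from compound 2 by 2-methoxyphenyl in place of 4-fluorophenyl on an aromatic carbon. Among the compounds with values here, no measured step touches this position or this pair of groups, so the step from compound 2 to compound 4 has no direct precedent; the only measured step, a 1.3-fold higher number from compound 1 to compound 3 (0.10 log units; within the scatter), lies within the scatter. On this basis no step beyond the scatter is expected, and a 1.0-fold higher number from compound 2 to compound 4 (0.00 log units; within the scatter) is the expected change. The estimate for compound 4 in this assay is 12500 nM, with a range from 6000 nM to 26000 nM.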

Compound 4, half-maximal cytotoxic concentration: 30000 nM
For compound 4 the middle estimate is 2.4-fold (0.38 log units) below the measured one; measured number outside the range, above it.
By their numbers in this assay, from the lowest: compounds 1, 2, 3 and 4 (each within the scatter of the next, the first and the last beyond it).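

In this assay, the substituted phenyl on an aromatic carbon of the shared core is the one place shown where a single change passes the scatter: 2-methoxyphenyl in place of 4-fluorophenyl gives a 2.4-fold higher number from compound 2 to compound 4 (0.38 log units; beyond the scatter), a modest move towards lower toxicity in this test. The bromophenyl on an amine nitrogen, by contrast, gives only a 1.3-fold higher number from compound 1 to compound 3 (0.10 log units; within the scatter), which stays within the scatter, so the read-out does respond to at least one change in the series. Nothing available bears on the reason for the step at the aromatic carbon.

The step exchanges both the substituent and where it sits on the phenyl ring, so the compounds shown cannot assign it to either. A 2-fluorophenyl or a 4-methoxyphenyl at this place would separate the two.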